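Swapping the pendant arm in a chemokine receptor antagonist series

The source may hold more compounds than are shown below. What is called first, only, known or untested is meant among the compounds shown, and "the series" means these compounds.

For the measured compounds named here, compound 3 `NCc1ccccc1CN(C[C@H]1Cc2ccccc2CN1)[C@H]1CCCc2cccnc21` is one of three compounds measured in a functional assay on cells for antagonist activity at C-X-C chemokine receptor type 4 (Homo sapiens), read by fluorescence and calcium flux, with stated times of 25 min and 90 s (on this read-out higher numbers stand for weaker inhibition and lower numbers for stronger inhibition), where compound 3 gives 50.8 nM. It stands second highest of the three numbers, with all three within the usual scatter of one another: compound 1 `c1ccc2c(c1)CN[C@@H](CN(CCCCNCC1CCNCC1)[C@H]1CCCc3cccnc31)C2` gives 36.5 nM, and compound 2 `c1ccc2c(c1)CN[C@@H](CN(CCCCNC1CCCCC1)[C@H]1CCCc3cccnc31)C2` gives 75.2 nM. Compound 4 `C(=C/CN(C[C@H]1Cc2ccccc2CN1)[C@H]1CCCc2cccnc21)\CNCc1ccccn1` has not yet been measured. It differs from compound 3 in one place: a group of 11 heavy atoms (9 carbon, 2 nitrogen; one six-membered aromatic ring with 1 hetero atom) in place of a group of 8 heavy atoms (7 carbon, 1 nitrogen; one six-membered aromatic ring of carbon only), on a saturated chain carbon bound to an amine nitrogen. Going by the values given here, the steps that bear on this, both changes at the same place, were a 1.4-fold higher number from compound 1 to compound 3 (0.14 log units; within the scatter) and a 1.5-fold lower number from compound 2 to compound 3 (0.17 log units; within the scatter); only a 2.1-fold higher number from compound 1 to compound 2 (0.31 log units; beyond the scatter) crossed the scatter. Compound 4 is therefore expected to shift by no more than a 1.1-fold lower number from compound 3 to compound 4 (0.05 log units; within the scatter). The estimated value for compound 4 in this assay is 45 nM, within 18 nM to 110 nM.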

Compound 4, half-maximal inhibitory concentration: 58.3 nM
Estimate against measurement, compound 4: 1.3-fold (0.11 log units) below; the range from low to high includes it.
By their numbers in this assay, from the lowest: compounds 1, 3, 4 and 2 (each within the scatter of the next, the first and the last beyond it).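

In this assay the entering arm, with one six-membered aromatic ring with 1 hetero atom and 1 double bond outside aromatic rings, stays within the scatter of all three earlier compounds, with a 1.1-fold higher number from compound 3 to compound 4 (0.06 log units; within the scatter) and a 1.3-fold lower number from compound 2 to compound 4 (0.11 log units; within the scatter) and a 1.6-fold higher number from compound 1 to compound 4 (0.20 log units; within the scatter) as the largest of these steps. This place, on a saturated chain carbon bound to an amine nitrogen, therefore accepts this arm with no step beyond the scatter. No measurement shown here accounts for this result.

On these data alone, whether a carboxylic acid or a longer saturated chain at this place would stay within that scatter remains open. So does the separate contribution of the double bond and of the ring's hetero atom.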